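A few compounds are considered here, and "the series" means these few. Any claim that something is new, unique, unknown or untested is made for them only; others in the source may bear on it.

Of the compounds shown here, three have been read so far in a physicochemical assay for solubility, read by HPLC, using the shake flask method, measured as kinetic solubility, with a stated time of 20 h, at pH 6.5, tested at 200 uM; a higher number here means a more soluble compound, a lower number a less soluble compound. Compound 1 `NS(=O)(=O)c1cncc(-c2ccc3nccc(-c4cn[nH]c4)c3n2)c1` gives < 5000 nM, which is a limit of the assay and not a number. Compound 3 `NS(=O)(=O)c1cccc(-c2ccc3nccc(-c4cccnc4)c3n2)c1` gives < 5000 nM, which is also a limit. Going by the values given here, compound 2 `O=S(=O)(c1cccc(-c2ccc3nccc(-c4ccncc4)c3n2)c1)N1CCC(O)CC1` gives 10000 nM, the only true number among the three, and so the one firm starting point.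

Compound 4 `C[C@@H]1CN(S(=O)(=O)c2cccc(-c3ccc4nccc(-c5ccncc5)c4n3)c2)C[C@H](C)N1` keeps the shared core of compound 2 and alters a single group: 3,5-dimethylpiperazin-1-yl in place of 4-hydroxypiperidin-1-yl on a sulfonyl sulfur. Put simply, 3,5-dimethylpiperazin-1-yl stands in place of 4-hydroxypiperidin-1-yl on a sulfonyl sulfur, and the new group brings 2 defined stereocentres. Among the compounds with values here, no two measured compounds differ in just one place, so the data give no direct measure of such a swap, and what follows is a judgement. A rise in this assay beyond the usual scatter is expected, starting from compound 2 at 10000 nM. The estimated size of this move is a 5.0-fold higher number from compound 2 to compound 4 (0.70 log units; beyond the scatter). For compound 4 the expected solubility is 50000 nM, with an estimated range of 15000 nM to 150000 nM.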

Compound 4, solubility: 180000 nM
Compound 4: middle estimate off by 3.6-fold (0.56 log units), on the low side; measured number outside the range, above it.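

The group on the sulfonyl sulfur is now shown to be a place where a single change can shift the reading: in this assay putting 3,5-dimethylpiperazin-1-yl in place of 4-hydroxypiperidin-1-yl gives an 18-fold higher number from compound 2 to compound 4 (1.26 log units; beyond the scatter) and this large step lies beyond the scatter. Going by these compounds alone, it is the first step measured here between two true numbers, and it appears although both groups are six-membered non-aromatic rings with the same counts of hydrogen-bond donors and acceptors and no net charge. Within the data shown here, compounds 1 and 3 give no step to set beside this one: the limit of < 5000 nM in this assay, at which 2 of the 4 values shown sit.

The swap alters the ring atoms and adds 2 defined stereocentres at once, and the data cannot separate these. Going by these compounds, whether a plain piperazine, a morpholine or an open-chain amine on the sulfonyl sulfur would read like compound 4 stays open.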